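Ring Amine Substituent Swap in F508del CFTR Binders

This account rests on a few compounds, and the source may have more. Where it says the series, first, only, none or still open, it means among the compounds named here.

Measured compounds:
compound 1 `CN(C)CCN1CCN(c2nc(-c3ccccn3)nc3c2CN(Cc2ccccc2)CC3)CC1`, 57%
compound 2 `CC(C)c1ccc(CN2CCc3nc(-c4ccccn4)nc(N4CCN(CCN(C)C)CC4)c3C2)cc1`, "not active" (no number reported)

In an assay on A549 cells with Cystic fibrosis transmembrane conductance regulator variant F508del (Homo sapiens) as the target, read by fluorescence, with a stated time of 25 min (a higher number here means a larger maximal response, a lower number a smaller maximal response), compound 1 reaches 57%. Compound 2 carries 4-isopropylbenzyl on the amine nitrogen in a ring where compound 1 carries benzyl, and in this assay compound 2 is reported as "not active" (no number reported), so no single number marks where it stands; only that it failed to give a measurable maximal response under the same conditions.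

Compound 3 `CN(C)CCN1CCN(c2nc(-c3ccccn3)nc3c2CN(S(=O)(=O)c2ccccc2)CC3)CC1` is the next member. It differs from compound 2 by phenylsulfonyl in place of 4-isopropylbenzyl on an amine nitrogen in a ring of a six-membered non-aromatic ring that is part of a fused system of two rings. Among the compounds with values here, no measured pair in this set isolates that exchange, so the size of the step from compound 2 to compound 3 in this assay cannot be taken from the data; with compound 2 reported as "not active" (no number reported), any recovery of a measurable response would be a change in the upward direction, but a repeat of inactivity is equally plausible. On this basis compound 3 is expected to give an estimated 30% in this assay, within a range from 5% to 60%.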

Compound 3, largest response reached (Emax), in percent of the reference or control that the assay uses: "not active" (no number reported)
Compound 3: no number reported, so the estimate cannot be set against anything.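

Within the data shown here, compound 2 and compound 3 are both reported as not active in this assay, so no step between them can be read. The compounds shown leave open whether any group other than the benzyl of compound 1 on the ring amine nitrogen gives a measurable maximal response. No evidence bears on this result.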